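Swapping phenoxy for a difluorobenzylamino group

A few compounds are considered here, and "the series" means these few. Any claim that something is new, unique, unknown or untested is made for them only; others in the source may bear on it.

compound 1 `O=C(O)C[C@H](NC(=O)c1cncc(S(=O)(=O)NC2CC2)c1)C(=O)Oc1ccccc1`: 4300 nM
compound 2 `CCN(CC)S(=O)(=O)c1cncc(C(=O)N[C@@H](CC(=O)O)C(=O)CSCc2ccc(F)cc2)c1`: 12000 nM
compound 3 `O=C(O)C[C@H](NC(=O)c1cncc(S(=O)(=O)NC2CC2)c1)C(=O)COC(=O)c1cccc2ccccc12`: 1300 nM

All three numbers come from a functional assay on NT2 cells (Homo sapiens) for inhibition; on this read-out higher numbers stand for weaker inhibition and lower numbers for stronger inhibition. Compound 1, at 4300 nM, sits in the middle of the three. Compound 2 has a higher number and compound 3 a lower one, and both gaps lie beyond the usual scatter.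

Compound 4 `O=C(O)C[C@H](NC(=O)c1cncc(S(=O)(=O)NC2CC2)c1)C(=O)CNCc1c(F)cccc1F` has not been measured yet. It carries ((2,6-difluorobenzyl)amino)methyl in place of phenoxy on a carbonyl carbon. Among the measured compounds shown here, no measured pair isolates this change, so the evidence is indirect. Compound 3 at 1300 nM and compound 2 at 12000 nM both carry other groups on that carbonyl carbon, and compound 2 also differs elsewhere. The entering group most resembles the fluorinated benzyl-containing group of compound 2, which points towards weaker inhibition. The expected step of a 1.6-fold higher number from compound 1 to compound 4 (0.21 log units; within the scatter) is small and may stay within the scatter. For compound 4 the estimate is 7000 nM, with an expected range of 2000 nM to 22000 nM.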

Compound 4, half-maximal inhibitory concentration: 53000 nM
The estimate for compound 4 lay 7.6-fold (0.88 log units) below the measured number; the whole stated range lies below it.
By their numbers in this assay, from the lowest: compound 3; then compound 1; then compound 2; then compound 4.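

In this assay, among the compounds shown here, this is the first direct comparison at this position: placing ((2,6-difluorobenzyl)amino)methyl on the carbonyl carbon in place of phenoxy, with the rest of the molecule unchanged, gives a 12-fold higher number from compound 1 to compound 4 (1.09 log units; beyond the scatter) and so much weaker inhibition. A single swap at this carbonyl carbon is therefore enough to shift the number well beyond the scatter. The entering group has more heavy atoms than phenoxy and adds a hydrogen-bond donor, but no available measurement shows what lies behind the loss.

The compounds shown do not separate the amine nitrogen from the two fluorines as contributors to this step. A benzyloxymethyl group, with oxygen in place of the nitrogen, or an unfluorinated (benzylamino)methyl group at the same carbon would test each part separately.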